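Compound 4 and the limit of the growth assay

The compounds below may be only part of what the source reports. "The series", "measured", "known", "first", "only" and "open" are said of these compounds alone.

Measured in an ADME assay on HS27 cells (Homo sapiens) for cytotoxicity, read by MTT assay, with a stated time of 24 h; a higher number here means a weaker inhibitor of growth, a lower number a stronger inhibitor of growth:
Compound 1 `Cc1ccc(NC(=O)C(c2ccc(Cl)cc2)c2ccc(Cl)cc2)cc1NC(=O)c1cnoc1C`: > 30000 nM
Compound 2 `Cc1ccc(NC(=O)Nc2ccccc2F)cc1NC(=O)c1cnoc1C`: > 30000 nM
Compound 3 `Cc1ccc(NC(=O)Nc2cccc(Cl)c2)cc1NC(=O)c1cnoc1C`: > 30000 nM

None of these three entries is a number, for each is a limit of the assay. The series offers one shared result, (the limit of > 30000 nM in this assay, at which 3 of the 3 values shown sit). Compound 3 therefore has no position of its own within a range of values. Its entry is the limit > 30000 nM.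

Compound 4 `Cc1ccc(NC(=O)Nc2cc(Cl)cc(Cl)c2)cc1NC(=O)c1cnoc1C` carries one change, (chloro in place of hydrogen on an aromatic carbon). In words, this is chloro in place of hydrogen on an aromatic carbon, so that 3-chlorophenyl becomes 3,5-dichlorophenyl.

Within the data shown here, the only measured step that bears on this change is a step that the two limits leave unreadable from compound 2 to compound 3. It also alters the substitution on the same phenyl group, but it supplies no size that could be carried over. Without a readable size, no step beyond the scatter is expected in this assay, and no direction can be given with any confidence. The expected change is a number no higher from compound 3 to compound 4 (the limit leaves the size open), and this is only an estimate. The assay will most probably report a limit again, though a true number cannot be ruled out. For compound 4 the estimated value is 30000 nM, with an expected range of 12000 nM to 60000 nM.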

Compound 4, concentration for 50% growth inhibition: > 30000 nM
Compound 4 ended at the assay's limit (the forecaster's own chance of this, stated with the estimate: 75%); the middle value sits exactly at the limit.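

In this assay compound 4 gives > 30000 nM, which is a limit of the assay and not a number. No size can be read for the step to compound 4 from compound 3 or from compound 2, and the series shares one result: the limit of > 30000 nM in this assay, at which 4 of the 4 values shown sit. The compounds shown leave open what concentration, if any, would inhibit growth for any of them.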